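From acetamido to amino on compound 2

The source may report more compounds than this note shows. Statements on the series, on what has been measured and on what is new or still open speak of the compounds shown alone.

compound 1 `COc1ccc(-c2oc3ccc(NC(C)=O)cc3c(=O)c2O)cc1`: 98700 nM
compound 2 `CC(=O)Nc1ccc2oc(-c3ccccc3F)c(O)c(=O)c2c1`: 171000 nM

Both values come from an ADME assay on MT4 cells (Homo sapiens) for cytotoxicity, read by MTT assay, with a stated time of 4 days; on this read-out lower numbers stand for higher toxicity in this test and higher numbers for lower toxicity in this test. Within the data shown here, compound 2 stands within the scatter of compound 1, its only measured neighbour. Compound 3 `Nc1ccc2oc(-c3ccccc3F)c(O)c(=O)c2c1` carries hydrogen in place of acetyl on a nitrogen on an aromatic ring, hydrogen in place of acetyl on a nitrogen on an aromatic ring. Among the measured compounds shown here, the one measured step, a 1.7-fold higher number from compound 1 to compound 2 (0.24 log units; within the scatter), swaps 4-methoxyphenyl for 2-fluorophenyl elsewhere, so it offers only a rough size. For the measured compounds named here, no measured step touches that nitrogen, which leaves the expectation loose. No change beyond the scatter is expected in this assay, and the expected step is a 1.6-fold lower number from compound 2 to compound 3 (0.19 log units; within the scatter). For compound 3 the estimate is 110000 nM, with an expected range of 40000 nM to 250000 nM.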

Compound 3, half-maximal cytotoxic concentration: 44500 nM
Estimate against measurement, compound 3: 2.5-fold (0.39 log units) above, within the range that was stated.
By their numbers in this assay, from the lowest: compound 3; then compounds 1 and 2 (each within the scatter of the next).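

In this assay, hydrogen in place of acetyl on a nitrogen on an aromatic ring gives a 3.8-fold lower number from compound 2 to compound 3 (0.58 log units; beyond the scatter). Among these compounds, this is the first step beyond the scatter, and it runs toward higher toxicity in this test, so this nitrogen can shift the read-out modestly. Nothing available bears on the reason for this step.

Going by these compounds, whether a propionyl or methanesulfonyl group on that nitrogen would stay with the acetamido or the amino compound remains open. Also open, on these data alone, is whether the same change gives a step of similar size with 4-methoxyphenyl in place of 2-fluorophenyl.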